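Swapping a bromine for a methyl on the outer pyrimidine ring

The source may hold more compounds than are shown below. What is called first, only, known or untested is meant among the compounds shown, and "the series" means these compounds.

Measured so far, in an assay on cells (Endothelial cell) for binding affinity to Endothelin-1 receptor (Sus scrofa); on this read-out lower numbers stand for stronger inhibition and higher numbers for weaker inhibition:
Compound 1, `COc1cccc(Oc2c(NS(=O)(=O)c3ccc(C(C)(C)C)cc3)ncnc2OCCO)c1`, gives 160 nM.
Compound 2, `COCCOc1ncnc(NS(=O)(=O)c2ccc(C(C)(C)C)cc2)c1Oc1cccc(OC)c1`, gives 92 nM.
Compound 3, `COc1cccc(Oc2c(NS(=O)(=O)c3ccc(C(C)(C)C)cc3)ncnc2OCCOc2ncc(Br)cn2)c1`, gives 0.051 nM.

Compound 3 has the lowest number of the three, and the gaps are large: a 1800-fold lower number from compound 2 to compound 3 (3.26 log units; beyond the scatter) and a 3100-fold lower number from compound 1 to compound 3 (3.50 log units; beyond the scatter). Both of these steps replace a small group on the chain-end oxygen with a 5-bromopyrimidin-2-yl group, so they show how much that ring contributes, but they say nothing about what happens when the substituent on that ring is altered.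

Compound 4, `COc1cccc(Oc2c(NS(=O)(=O)c3ccc(C(C)(C)C)cc3)ncnc2OCCOc2nccc(C)n2)c1`, takes exactly that unexplored step: 4-methylpyrimidin-2-yl in place of 5-bromopyrimidin-2-yl on an oxygen on a saturated carbon. The ring and its attachment point are kept; only the substituent on the ring changes. Within the data shown here, no measured step bears directly on this exchange, so the expectation rests on the ring itself being retained. A modest loss relative to compound 3 is expected, a 5.9-fold higher number from compound 3 to compound 4 (0.77 log units; beyond the scatter), with wide uncertainty. Compound 4 is therefore estimated at 0.3 nM in this assay, within a range of 0.04 nM to 3 nM.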

Compound 4, half-maximal inhibitory concentration: 39.4 nM
Beside the measured number, compound 4's estimate is 130-fold (2.12 log units) below it, and the stated range ends below it.
By their numbers in this assay, from the lowest: compound 3; then compound 4; then compounds 2 and 1 (each within the scatter of the next).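

In this assay, keeping the pyrimidine ring on the chain-end oxygen does not by itself keep the low number: there is a 770-fold higher number from compound 3 to compound 4 (2.89 log units; beyond the scatter) when 4-methylpyrimidin-2-yl replaces 5-bromopyrimidin-2-yl. The ring with this methyl retains only a modest advantage over the small groups, with a 2.3-fold lower number from compound 2 to compound 4 (0.37 log units; beyond the scatter) and a 4.1-fold lower number from compound 1 to compound 4 (0.61 log units; beyond the scatter), so the very large gain seen with compound 3 depends on what the ring carries and where, not on the ring alone. Nothing available here explains why these two rings differ so sharply.

Compound 4 changes both the substituent and its place on the ring, so 5-methylpyrimidin-2-yl and 4-bromopyrimidin-2-yl would be needed to tell these two changes apart. Going by these compounds, whether a chlorine or an amine on the ring could also reach such low numbers remains open.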